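This account rests on a few compounds, and the source may have more. Where it says the series, first, only, none or still open, it means among the compounds named here.

Within the data shown here, in a functional assay on RAW264.7 cells (Mus musculus) for inhibition, read by Griess assay, with a stated time of 24 h (on this read-out lower numbers stand for stronger inhibition and higher numbers for weaker inhibition), compound 2 (`O=C(S[C@@]12CC[C@H](O)[C@@H]1C(=O)NC2=O)c1ccccc1`) gives 72400 nM as the lower of the two numbers so far, while compound 1 (`O=C(S[C@]12CC[C@H](O)[C@H]1C(=O)NC2=O)c1ccccc1Cl`) gives 178000 nM as the higher, a gap beyond the scatter. Compound 3 (`O=C(S[C@]12CC[C@H](O)[C@H]1C(=O)NC2=O)c1ccccc1`) has the same atoms and bonds as compound 2, and the two compounds have the same atoms and bonds and differ only in configuration as drawn: 2 of 3 stereo elements differ; a stereocentre at a saturated ring carbon is drawn S in compound 2 and R in compound 3; a stereocentre at a saturated ring carbon is drawn R in compound 2 and S in compound 3 is the whole difference between them. Among the measured compounds shown here, no measured pair shows a change of this kind, so only a modest rise in the number, meaning weaker inhibition, is expected. The expected move is a 1.4-fold higher number from compound 2 to compound 3 (0.14 log units; within the scatter) on this estimate. The estimated value for compound 3 is 100000 nM with a range from 40000 nM to 250000 nM expected.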

Compound 3, half-maximal inhibitory concentration: 65200 nM
The estimate for compound 3 lay 1.5-fold (0.19 log units) above the measured number; low and high end bracket the measured number.
By their numbers in this assay, from the lowest: compounds 3 and 2 (each within the scatter of the next); then compound 1.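

In this assay, the change in configuration gives a 1.1-fold lower number from compound 2 to compound 3 (0.05 log units; within the scatter), so the configuration as drawn at these two saturated ring carbons does not separate the pair. Among these compounds, with the configuration of compound 3 held fixed, hydrogen in place of chloro on an aromatic carbon gives a 2.7-fold lower number from compound 1 to compound 3 (0.44 log units; beyond the scatter), which is the only step here beyond the scatter. The reading of the first step as a pure test of configuration rests on one fact: the fact that compounds 2 and 3 differ only in the configuration as drawn

From the compounds shown here alone, whether a fluoro or methoxy group on that aromatic carbon would shift the number remains open. So does whether the chloro step holds in the configuration of compound 2.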